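Swapping a thiophene for trifluoromethylphenyl in an imine series

The source may report more compounds than this note shows. Statements on the series, on what has been measured and on what is new or still open speak of the compounds shown alone.

Measured so far:
compound 1 `CN1CCN(c2ccc(Nc3ncc(/N=C/c4cccs4)c(NC4CCCC4)n3)cc2)CC1`, 21700 nM in a functional assay on HT-29 cells (Homo sapiens) for antiproliferative activity, read by MTT assay; a lower number here means a stronger inhibitor, a higher number a weaker inhibitor
compound 2 `CN1CCN(c2ccc(Nc3ncc(/N=C/c4ccc(C(F)(F)F)cc4)c(NC4CCCC4)n3)cc2)CC1`, 80700 nM in this assay
compound 3 `CC(C)Nc1nc(Nc2ccc(S(N)(=O)=O)cc2)ncc1/N=C/c1cccs1`, > 100000 nM in this assay

Compound 3 gives only a limit in this assay, not a number; (the limit of > 100000 nM in this assay, at which 1 of the 3 values shown sits). The difference between the core of compound 1 and the core of compound 3 is not broken down here. Compound 4 `CC(C)Nc1nc(Nc2ccc(S(N)(=O)=O)cc2)ncc1/N=C/c1ccc(C(F)(F)F)cc1` is not yet measured. It carries the same change as is made from compound 1 to compound 2: 4-(trifluoromethyl)phenyl in place of thiophen-2-yl on a carbon with a double bond to nitrogen, which gave a 3.7-fold higher number from compound 1 to compound 2 (0.57 log units; beyond the scatter). The change from compound 3 to compound 4 is 4-(trifluoromethyl)phenyl in place of thiophen-2-yl on a carbon with a double bond to nitrogen. Because the measured instance of this change gave a 3.7-fold higher number from compound 1 to compound 2 (0.57 log units; beyond the scatter), a weakening of similar size is expected from compound 3 to compound 4, as a step that the limit leaves unreadable from compound 3 to compound 4. Compound 4 is therefore expected to give about 370000 nM in this assay, between 100000 nM and 1500000 nM, and most likely again only a limit.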

Compound 4, half-maximal inhibitory concentration: > 100000 nM
Compound 4: no number, only a limit (the forecaster's own chance of this, stated with the estimate: 90%); the middle value is on the limit's open side.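

Compound 3 and compound 4 each give only a limit in this assay, so no step between them can be read: the limit of > 100000 nM in this assay, at which 2 of the 4 values shown sit.

As far as these compounds go, whether this swap changes activity at all on the core shared by compound 3 and compound 4 stays open.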